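This account rests on a few compounds, and the source may have more. Where it says the series, first, only, none or still open, it means among the compounds named here.

Compound 2 `Cc1nc(-c2cccnc2)sc1-c1nnc(-c2ccccc2Cl)o1` is the starting point. In an ADME assay on HeLa cells (Homo sapiens) for cytotoxicity, read by MTT assay (a lower number here means that less compound is tolerated, a higher number that more compound is tolerated), compound 2 gives > 100 ug/mL, which is a limit of the assay rather than a number. Its two measured neighbours, compound 1 `Cc1nc(-c2cccnc2)sc1-c1nnc(Cc2ccccc2)o1` and compound 3 `Cc1ccccc1-c1nnc(-c2sc(-c3cccnc3)nc2C)o1`, offer no firmer footing. Compound 1 gives > 100 ug/mL in this assay, again a limit. Compound 3 gives > 100 ug/mL in this assay, once more a limit. All three values thus rest at the limit of > 100 ug/mL in this assay, at which 3 of the 3 values shown sit, and none of the steps among them can be read: a step that the two limits leave unreadable from compound 1 to compound 2, a step that the two limits leave unreadable from compound 1 to compound 3 and a step that the two limits leave unreadable from compound 2 to compound 3.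

Compound 4 `Cc1nc(-c2cccnc2)sc1-c1nnc(-c2ccc(O)cc2)o1` has not been measured. Its change from compound 2 is 4-hydroxyphenyl in place of 2-chlorophenyl on an aromatic carbon. Going by the values given here, the measured steps that bear on this change are the three just named, and since each is unreadable they give neither a size nor a direction; they show only that exchanging the group on an aromatic carbon of the shared core among benzyl, 2-chlorophenyl and 2-methylphenyl left every compound at the limit. A step beyond the scatter in this assay is therefore not expected in either direction. Compound 4 is expected to give 100 ug/mL in this assay, with a range from 50 ug/mL to 200 ug/mL. The step that this estimate means is expected to be a number no higher from compound 2 to compound 4 (the limit leaves the size open).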

Compound 4, half-maximal cytotoxic concentration: > 100 ug/mL
Compound 4 ended at the assay's limit; the forecaster's own chance of this, stated with the estimate: 85%; the middle value lies on the limit itself.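

In this assay, going by these compounds alone, compound 4 gives > 100 ug/mL (a limit of the assay), so its steps to compound 1, compound 2 and compound 3 cannot be read, and no new step emerges. The compounds shown leave open whether benzyl, 2-chlorophenyl, 2-methylphenyl and 4-hydroxyphenyl differ at all in how much compound is tolerated.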